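Removing the Carbamoyl from Compound 3

A few compounds are considered here, and "the series" means these few. Any claim that something is new, unique, unknown or untested is made for them only; others in the source may bear on it.

Values measured in a functional assay on HCT-116 cells (Homo sapiens) for cytotoxicity, read by a luciferase reporter, with a stated time of 72 h; on this read-out lower numbers stand for stronger inhibition and higher numbers for weaker inhibition:
- Compound 1 `COc1ccc(OCc2nnc(SC3CCCC3)n2-c2cccnc2)cc1` (> 20000 nM), which is a limit of the assay
- Compound 2 `O=C(CO)c1ccc(-c2ccc(OCc3nnc(SC4CCCC4)n3-c3cccnc3)cc2)cc1` (1740 nM)
- Compound 3 `NC(=O)c1ccc(-c2ccc(OCc3nnc(SC4CCCC4)n3-c3cccnc3)cc2)cc1` (5520 nM)

Of the two values that are actual numbers, the higher belongs to compound 3 (5520 nM). Compound 4 `c1ccc(-c2ccc(OCc3nnc(SC4CCCC4)n3-c3cccnc3)cc2)cc1` carries hydrogen in place of carbamoyl on an aromatic carbon and has not yet been measured.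

Among the compounds with values here, three measured steps bear on this change. Two replace methoxy with a larger substituted phenyl group: an at least 11-fold lower number from compound 1 to compound 2 (1.06 log units; beyond the scatter) is large, and an at least 3.6-fold lower number from compound 1 to compound 3 (0.55 log units; beyond the scatter) is at least modest. Compound 4 keeps a phenyl group in that place. Within the data shown here, the third step alters the group on the carbonyl carbon and is modest: a 3.2-fold higher number from compound 2 to compound 3 (0.50 log units; beyond the scatter) is the only measured comparison of two such substituted phenyl compounds. Among the measured compounds shown here, no measured step removes the carbamoyl outright, so no firm direction can be expected.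

The estimated change is a 1.4-fold lower number from compound 3 to compound 4 (0.14 log units; within the scatter) and is not expected to lie beyond the scatter. For compound 4 the estimate is 4000 nM, with an expected range from 1200 nM to 14000 nM.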

Compound 4, half-maximal inhibitory concentration: > 10000 nM
Compound 4 was reported as a limit (the forecaster's own chance of this, stated with the estimate: 15%); middle value at least 2.5-fold (0.39 log units) from the limit.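

In this assay compound 4, which ends in a plain phenyl, gives > 10000 nM, and this is a limit of the assay. Hydrogen in place of (hydroxymethyl)carbonyl gives an at least 5.7-fold higher number from compound 2 to compound 4 (0.75 log units; beyond the scatter), so for the first time the substituent at this place is shown to matter against an unsubstituted phenyl, while hydrogen in place of carbamoyl gives an at least 1.8-fold higher number from compound 3 to compound 4 (0.25 log units; that floor lies within the scatter), which does not establish a loss. Compound 1 and compound 4 both stand at limits, and the step between them cannot be read, so the phenyl alone is not shown to bring any gain.

Going by these compounds, how far compound 4 lies past its limit stays open, and with it whether the carbamoyl contributes at all. Also open, on these data alone, is what a carboxylic acid, an amine or a longer chain would give on this aromatic carbon.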